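The source may report more compounds than this note shows. Statements on the series, on what has been measured and on what is new or still open speak of the compounds shown alone.

Measured so far in a functional assay on HeLa cells (Homo sapiens) for inhibition, read by MTT assay, with a stated time of 72 h; on this read-out lower numbers stand for stronger inhibition and higher numbers for weaker inhibition:

compound 1, `CNC(=O)CCCCCCCn1nc(-c2ccc3oc(N)nc3c2)c2c(N)ncnc21`: 12900 nM
compound 2, `Nc1nc2cc(-c3nn(CCCCCC(=O)NO)c4ncnc(N)c34)ccc2o1`: 15400 nM
compound 3, `Nc1nc2cc(-c3nn(CCCCCCCCCC(=O)NO)c4ncnc(N)c34)ccc2o1`: the value is a limit of the assay, > 50000 nM

All three share one core and differ only in the side chain that hangs from an aromatic nitrogen. Compound 2 sits at the top of the two plain numbers, with compound 1 nearest to it; that gap, a 1.2-fold higher number from compound 1 to compound 2 (0.08 log units; within the scatter), is too small to count as a difference. Compound 3 stands apart: its result is only a limit, so its true value is not known, and the chain that was lengthened on the way there, an at least 3.2-fold higher number from compound 2 to compound 3 (0.51 log units; beyond the scatter), made the number at least modestly worse.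

Compound 4, `Nc1nc2cc(-c3nn(CC(=O)NO)c4ncnc(N)c34)ccc2o1`, is the unmeasured partner. It differs from compound 2 in that (hydroxycarbamoyl in place of 4-(hydroxycarbamoyl)butyl on a saturated chain carbon bound to an aromatic nitrogen). The side chain is thus cut short rather than lengthened. Among the compounds with values here, the only directly related step, an at least 3.2-fold higher number from compound 2 to compound 3 (0.51 log units; beyond the scatter), shows that adding length hurt, and an at least 3.8-fold higher number from compound 1 to compound 3 (0.58 log units; beyond the scatter) points the same way, but no measured step shows what removing length does. The expectation is therefore uncertain and leans only slightly toward a weaker result, a 1.6-fold higher number from compound 2 to compound 4 (0.21 log units; within the scatter).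

Compound 4 is expected to give about 25000 nM, within a range from 8000 nM to 80000 nM.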

Compound 4, half-maximal inhibitory concentration: > 150000 nM
Compound 4 gave a limit, no number; the forecaster's own chance of this, stated with the estimate: 25%; middle value at least 6.0-fold (0.77 log units) away from the limit.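

In this assay, compound 4, whose side chain is cut down to (hydroxycarbamoyl)methyl, reached only a limit of the assay rather than a number: the limit of > 150000 nM in this assay, at which 1 of the 4 values shown sits.

Even so, the change from 5-(hydroxycarbamoyl)pentyl to (hydroxycarbamoyl)methyl on this saturated chain carbon bound to an aromatic nitrogen is readable as an at least 9.7-fold higher number from compound 2 to compound 4 (0.98 log units; beyond the scatter), and replacing the 6-(methylcarbamoyl)hexyl group gives an at least 11-fold higher number from compound 1 to compound 4 (1.06 log units; beyond the scatter). The earlier compounds shown here showed only that a longer chain raised the number, as in an at least 3.2-fold higher number from compound 2 to compound 3 (0.51 log units; beyond the scatter), whereas this result shows that a much shorter chain raises it too. Among the three compounds ending in hydroxycarbamoyl, the middle chain of compound 2 therefore gives the lowest number, with both the longer and the shorter chain beyond the scatter from it.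

Within the data shown here, compound 3 and compound 4 both stand as limits, so no step between them can be read, and how far either really lies from compound 2 remains unknown. Also open, going by these compounds, is whether a chain of intermediate length, or a carboxylic acid or an amine in place of the hydroxycarbamoyl end, would bring the number lower than that of compound 2.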